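Trading an azetidine amide for a cyclopropyl amide

The source may report more compounds than this note shows. Statements on the series, on what has been measured and on what is new or still open speak of the compounds shown alone.

In an assay on a protein complex for inhibition of CDK8/Cyclin C (Homo sapiens), with a stated time of 1 h (a higher number here means a weaker inhibitor, a lower number a stronger inhibitor), compound 1 `O=C(O)/C=C/c1ccncc1-c1ccc2cc[nH]c2c1` gives 2.4 nM, the lowest of the three numbers in hand. Compound 2 `COC1CN(C(=O)/C=C/c2ccncc2-c2ccc3ccccc3c2)C1` gives 42.8 nM in this assay, which places it second highest of the three. Its nearest neighbour is compound 3 `Cn1ccc2cc(-c3cnccc3/C=C/C(=O)N3CCOCC3)ccc21` at 247 nM, a gap beyond the usual scatter, while compound 1 lies furthest away, also beyond the scatter. Compound 4 `O=C(/C=C/c1ccncc1-c1ccc2ccccc2c1)NC1CC1` has not yet been measured. It differs from compound 2 in one place: cyclopropylamino in place of 3-methoxyazetidin-1-yl on a carbonyl carbon. The 3-methoxyazetidin-1-yl group leaves and cyclopropylamino enters on the carbonyl carbon. Among the compounds with values here, no measured pair shows this exact change, so the size of the step is open. Compound 1, with its free acid, gives the lowest number, but both amides differ from it in more than one place, so nothing firm carries over to compound 4. Compound 4 is expected to land close to compound 2, with the step of a 1.4-fold lower number from compound 2 to compound 4 (0.15 log units; within the scatter) small and not beyond the scatter. Compound 4 is estimated at 30 nM in this assay, with a range from 10 nM to 120 nM.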

Compound 4, half-maximal inhibitory concentration: 40.1 nM
Beside the measured number, compound 4's estimate is 1.3-fold (0.13 log units) below it, within the range that was stated.
By their numbers in this assay, from the lowest: compound 1; then compounds 4 and 2 (each within the scatter of the next); then compound 3.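

In this assay, within the data shown here, the first comparison at this position that changes only one place gives a 1.1-fold lower number from compound 2 to compound 4 (0.03 log units; within the scatter). The carbonyl carbon can therefore carry either 3-methoxyazetidin-1-yl or cyclopropylamino with no difference that these measurements can resolve. The two groups are not alike on paper: the leaving group has 6 heavy atoms, a four-membered ring and 1 hydrogen-bond acceptor, whereas the entering group has 4 heavy atoms, a three-membered ring and 1 hydrogen-bond donor, yet the numbers for the two compounds stay within the usual scatter.

This single pair swaps several features at once, so it cannot show how each one counts alone, and a group such as dimethylamino, which has no amide hydrogen and no ring, or piperazin-1-yl, which is a larger ring with a second nitrogen, would test this position further. As far as these compounds go, no measurement here gives a reason why the two amides match, and whether that match would hold on another core also stays open.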